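The source may report more compounds than this note shows. Statements on the series, on what has been measured and on what is new or still open speak of the compounds shown alone.

Compound 1, `Cc1cnn(C(=O)N2CCCCC2)c1`, is measured in an assay on membranes from brain for binding affinity to Monoacylglycerol lipase ABHD6 (Mus musculus), read by fluorescence, with stated times of 1 h and 30 min (a lower number here means a stronger inhibitor, a higher number a weaker inhibitor), and gives 1100 nM. Compound 2, `O=C(N1CCCCC1)n1cccn1`, gives in this assay 5000 nM. The step between them, a 4.5-fold higher number from compound 1 to compound 2 (0.66 log units; beyond the scatter), comes from one change, (hydrogen in place of methyl on an aromatic carbon). Compound 3, `Cc1cnn(C(=O)N(C)CCN(C)C(c2ccc(OCc3ccccc3)cc2)c2ccc(OCc3ccccc3)cc2)c1`, carries the same methyl-bearing five-membered ring on a much larger amide part; how its core differs from the core of compound 1 is not broken down here. In this assay compound 3 reaches only a limit of the assay, > 1000000 nM, and no number is known for it (the limit of > 1000000 nM in this assay, at which 1 of the 3 values shown sits). Compound 4, `CN(CCN(C)C(c1ccc(OCc2ccccc2)cc1)c1ccc(OCc2ccccc2)cc1)C(=O)n1cccn1`, is not yet measured in this assay. It differs from compound 3 by hydrogen in place of methyl on an aromatic carbon, the same kind of change as that from compound 1 to compound 2, though here the ring atom bears a large group rather than a group of 8 heavy atoms. Given a 4.5-fold higher number from compound 1 to compound 2 (0.66 log units; beyond the scatter), the step that the limit leaves unreadable from compound 3 to compound 4 is expected to make the number higher still. Compound 4 is therefore estimated at 3000000 nM, between 800000 nM and 20000000 nM, most likely again reported only as a limit.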

Compound 4, half-maximal inhibitory concentration: > 1000000 nM
Compound 4 was reported as a limit; the forecaster's own chance of this, stated with the estimate: 90%; the middle value is on the limit's open side.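

Compound 3 and compound 4 each stand only at a limit in this assay and no number is known for either, so no step can be read between them: the limit of > 1000000 nM in this assay, at which 2 of the 4 values shown sit. The compounds shown leave open whether hydrogen in place of methyl changes the number on the large amide part of compound 3 and compound 4 as it does from compound 1 to compound 2.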